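The compounds below may be only part of what the source reports. "The series", "measured", "known", "first", "only" and "open" are said of these compounds alone.

Compound 3 `Cc1nn(-c2ncnc3nc[nH]c23)c2c1C(OCc1ccccc1Cl)CC(=O)N2` gives 47 nM in a functional assay on HEK293 cells for agonist activity at G-protein coupled receptor 39 (Homo sapiens), read by scintillation proximity assay and inositol phosphate accumulation, with a stated time of 75 min; on this read-out higher numbers stand for an effect only at larger amounts of compound and lower numbers for an effect already at smaller amounts; it stands second highest of three numbers, with compound 2 `Cc1nn(-c2ncnc3nc[nH]c23)c2c1C(OCCc1ccccc1)CC(=O)N2` at 40 nM and compound 1 `Cc1nn(-c2ncnc3nc[nH]c23)c2c1C(OC1CCCC1)CC(=O)N2` at 62 nM, both within the scatter of it. Compound 4 `Cc1nn(-c2ncnc3nc[nH]c23)c2c1C(OC(=O)c1ccc(F)cc1)CC(=O)N2` differs from compound 3 by (4-fluorophenyl)carbonyl in place of 2-chlorobenzyl on an oxygen on a saturated carbon. Among the compounds with values here, the steps that bear on this change vary the same group on the same oxygen: a 1.3-fold lower number from compound 1 to compound 3 (0.12 log units; within the scatter) and a 1.2-fold higher number from compound 2 to compound 3 (0.07 log units; within the scatter), while a 1.6-fold lower number from compound 1 to compound 2 (0.19 log units; within the scatter) likewise stays within the scatter. Cyclopentyl, phenethyl and 2-chlorobenzyl all leave the number essentially unchanged, so no step beyond the scatter is expected for compound 4, though a carbonyl on this oxygen is untested in the series. Compound 4 is estimated at 80 nM, range 25 nM to 300 nM. The step of a 1.7-fold higher number from compound 3 to compound 4 (0.23 log units; within the scatter) is thus expected.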

Compound 4, half-maximal effective concentration: 245 nM
Compound 4: middle estimate off by 3.1-fold (0.49 log units), on the low side; low and high end bracket the measured number.
By their numbers in this assay, from the lowest: compounds 2, 3 and 1 (each within the scatter of the next); then compound 4.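

(4-Fluorophenyl)carbonyl is the first group on this oxygen to move the number beyond the scatter: a 5.2-fold higher number from compound 3 to compound 4 (0.72 log units; beyond the scatter), a 6.1-fold higher number from compound 2 to compound 4 (0.79 log units; beyond the scatter) and a 4.0-fold higher number from compound 1 to compound 4 (0.60 log units; beyond the scatter). The position therefore does respond to its substituent, even though cyclopentyl, phenethyl and 2-chlorobenzyl could not be told apart. Nothing at hand explains the step.

Going by these compounds, the change from compound 3 brings in the carbonyl and swaps the halogen at once, so the two cannot be separated. (2-Chlorophenyl)carbonyl or unsubstituted benzoyl on this oxygen would separate them, and a free hydroxyl on the saturated carbon remains open too.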